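One Aryl Swap, Tested Twice on Related Cores

This account rests on a few compounds, and the source may have more. Where it says the series, first, only, none or still open, it means among the compounds named here.

Compound 1 `COc1ccc2nc(NC(c3cn(-c4ccccc4)nc3-c3ccc(Cl)cc3)c3c(O)ccc4ccccc34)sc2c1` in a functional assay on HeLa cells (Homo sapiens) for antiproliferative activity, read by MTT assay, with a stated time of 48 h (on this read-out lower numbers stand for stronger inhibition and higher numbers for weaker inhibition), gives 5200 nM.
Compound 2 `COc1cccc(-c2nn(-c3ccccc3)cc2C(Nc2nc3ccc(OC)cc3s2)c2c(O)ccc3ccccc23)c1` in this assay gives 10500 nM.
Compound 3 `COc1cccc(-c2nn(-c3ccccc3)cc2C(Nc2nc3ccc(Cl)cc3s2)c2c(O)ccc3ccccc23)c1` in this assay gives 30000 nM.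

Compound 4 `Oc1ccc2ccccc2c1C(Nc1nc2ccc(Cl)cc2s1)c1cn(-c2ccccc2)nc1-c1ccc(Cl)cc1` has not yet been measured. It differs from compound 3 by one change: 4-chlorophenyl in place of 3-methoxyphenyl on an aromatic carbon. The same change has already been made once, from compound 2 to compound 1, as 4-chlorophenyl in place of 3-methoxyphenyl on an aromatic carbon, and there it produced a 2.0-fold lower number from compound 2 to compound 1 (0.31 log units; beyond the scatter). The two cores on which the swap is made differ from each other by chloro in place of methoxy on an aromatic carbon, a change that on its own gave a 2.9-fold higher number from compound 2 to compound 3 (0.46 log units; beyond the scatter). The place of the swap reads the same in both pairs, so this is the same change carried onto a different core. The step expected from compound 3 to compound 4 is a 2.0-fold lower number from compound 3 to compound 4 (0.30 log units; within the scatter), resting on the earlier step of a 2.0-fold lower number from compound 2 to compound 1 (0.31 log units; beyond the scatter). Compound 4 is therefore expected to give about 15000 nM in this assay, within a range from 6000 nM to 40000 nM.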

Compound 4, half-maximal inhibitory concentration: 36800 nM
Compound 4: middle estimate off by 2.5-fold (0.39 log units), on the low side; measured number inside the range.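

In this assay, the swap to 4-chlorophenyl gives a 1.2-fold higher number from compound 3 to compound 4 (0.09 log units; within the scatter), and this step does not differ meaningfully from the one seen on the other core: the same change on two cores in this assay, a 2.0-fold lower number (0.31 log units; beyond the scatter) from compound 2 to compound 1 and a 1.2-fold higher number (0.09 log units; within the scatter) from compound 3 to compound 4, 2.5-fold (0.39 log units) apart, within the scatter of two such steps. The chloro in place of methoxy change also holds up across the two cores, giving a 7.1-fold higher number from compound 1 to compound 4 (0.85 log units; beyond the scatter) and again staying close to its earlier step: the same change on two cores in this assay, a 2.9-fold higher number (0.46 log units; beyond the scatter) from compound 2 to compound 3 and a 7.1-fold higher number (0.85 log units; beyond the scatter) from compound 1 to compound 4, 2.5-fold (0.39 log units) apart, within the scatter of two such steps. These two pairs fit each change carrying over between these two cores, but they do not show that it would carry over to other cores in the series, and they do not explain why either step occurs.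

From the compounds shown here alone, whether an amine or a carboxylic acid in place of the chloro or methoxy group would shift these numbers remains open. So does whether the swap to 4-chlorophenyl would keep the same size on a core carrying either group.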